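Isopropyl on the amidine nitrogen: expected cytotoxicity shift

The source may hold more compounds than are shown below. What is called first, only, known or untested is meant among the compounds shown, and "the series" means these compounds.

The three measured compounds share one core. Compound 1 `CC(C)NC(=N)c1ccc2cc(-c3cccc(OCCCOc4ccccc4)c3)oc2c1` and compound 2 `CC(C)NC(=N)c1ccc2cc(-c3cccc(OCCCCOc4ccccc4)c3)oc2c1` carry an isopropylamidine, while compound 3 `N=C(N)c1ccc2cc(-c3cccc(OCCCCCOc4ccccc4)c3)oc2c1` has the unsubstituted amidine together with the longest linker. In an ADME assay on L6 cells (Rattus norvegicus) for cytotoxicity, read by resazurin assay, with a stated time of 70 h (a higher number here means a weaker inhibitor, a lower number a stronger inhibitor), compound 1 gives 82300 nM, compound 2 gives 46500 nM and compound 3 gives 4100 nM. Compound 3 therefore stands lowest of the three numbers, beyond the scatter from both others. For the measured compounds named here, the only single-place step, a 1.8-fold lower number from compound 1 to compound 2 (0.25 log units; within the scatter), shows that lengthening the linker leaves the number essentially unchanged.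

Compound 4 `CC(C)NC(=N)c1ccc2cc(-c3cccc(OCCCCCOc4ccccc4)c3)oc2c1` is compound 3 with isopropyl in place of hydrogen on an amine nitrogen. Going by the values given here, no measured pair isolates this change. Compound 2 and compound 3 differ in both the linker and this group, and given a 1.8-fold lower number from compound 1 to compound 2 (0.25 log units; within the scatter) the linker part seems to contribute little, so the gap between compound 2 and compound 3 points to the isopropyl raising the number. The expected step is a 6.1-fold higher number from compound 3 to compound 4 (0.79 log units; beyond the scatter), upward and beyond the scatter. For compound 4 the estimate is 25000 nM, with a range from 6000 nM to 80000 nM.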

Compound 4, half-maximal inhibitory concentration: 20100 nM
Compound 4: middle estimate off by 1.2-fold (0.09 log units), on the high side; low and high end bracket the measured number.
By their numbers in this assay, from the lowest: compound 3; then compound 4; then compounds 2 and 1 (each within the scatter of the next).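

In this assay, for the compounds shown here, the step of a 4.9-fold higher number from compound 3 to compound 4 (0.69 log units; beyond the scatter) isolates isopropyl in place of hydrogen on the amine nitrogen for the first time, and it shows that this change alone raises the number at the longest linker. Among the isopropylamidines, the linker now has a visible effect: a 2.3-fold lower number from compound 2 to compound 4 (0.36 log units; beyond the scatter) and a 4.1-fold lower number from compound 1 to compound 4 (0.61 log units; beyond the scatter) both lie beyond the scatter, whereas the earlier step between the two shorter linkers, a 1.8-fold lower number from compound 1 to compound 2 (0.25 log units; within the scatter), stayed within it. Both linker steps point downward, so the longest linker carries the lowest number of the three isopropylamidines.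

Still open, from the compounds shown here alone, is how other groups on this nitrogen, such as cyclopropyl or a longer chain, would compare with isopropyl, and whether the isopropyl step keeps its size at shorter linkers. Nothing in the data shown gives a reason for either shift.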